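The compounds below may be only part of what the source reports. "The series", "measured", "known", "first", "only" and "open" are said of these compounds alone.

Measured compounds:
compound 1 `CC(=O)N1N=C(c2ccco2)CC1c1ccc(N(C)C)cc1` with 16700 nM
compound 2 `CC(=O)N1N=C(c2cccc3ccccc23)CC1c1ccccc1[N+](=O)[O-]` with 3540 nM
compound 3 `CC(=O)N1N=C(c2cccc3ccccc23)CC1c1cccc(Cl)c1Cl` with 20100 nM

In a functional assay on PC-3 cells (Homo sapiens) for cytotoxicity, read by sulforhodamine B assay, with a stated time of 48 h (a higher number here means a weaker inhibitor, a lower number a stronger inhibitor), compound 3 gives the highest of the three numbers, although the gap to compound 1 lies within the scatter, so the two cannot be ordered; only compound 2 stands clearly apart, with a lower number. Among the compounds with values here, the one step that touches the group on the saturated ring carbon is a 5.7-fold higher number from compound 2 to compound 3 (0.75 log units; beyond the scatter), and it went from an aromatic ring bearing a nitro group to one bearing two chlorines. Compound 4 `CC(=O)N1N=C(c2cccc3ccccc23)CC1c1cccc(Br)c1` carries the change (3-bromophenyl in place of 2,3-dichlorophenyl on a saturated ring carbon). Within the data shown here, no measured pair swaps one halogen-bearing ring for another, so that step gives only a loose guide: the shared core is the same and the ring keeps its size. The expected step of a 1.3-fold lower number from compound 3 to compound 4 (0.13 log units; within the scatter) is therefore small, with no direction claimed beyond the scatter. Compound 4 is estimated at 15000 nM in this assay, within the range 5000 nM to 45000 nM.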

Compound 4, half-maximal inhibitory concentration: 12000 nM
Estimate against measurement, compound 4: 1.3-fold (0.10 log units) above; measured number inside the range.
By their numbers in this assay, from the lowest: compound 2; then compounds 4, 1 and 3 (each within the scatter of the next).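

In this assay, the exchange of 2,3-dichlorophenyl for 3-bromophenyl on the saturated ring carbon gives a 1.7-fold lower number from compound 3 to compound 4 (0.22 log units; within the scatter), so these two halogen-bearing rings cannot be told apart at this position. The step of a 3.4-fold higher number from compound 2 to compound 4 (0.53 log units; beyond the scatter) lies beyond the scatter, as does a 5.7-fold higher number from compound 2 to compound 3 (0.75 log units; beyond the scatter), so on this shared core compound 2, with its 2-nitrophenyl group, stands apart from both halogen-bearing compounds, and that separation no longer rests on a single halogen pattern.

The compounds shown leave open whether the lower number of compound 2 belongs to the nitro group itself or to its place on the ring, and whether another group there, such as an amine or a carboxylic acid, would fall with compound 2 or with compound 3 and compound 4. No independent measurement is available that accounts for this separation.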